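A Smaller Group Takes Over the Saturated Ring

The compounds below may be only part of what the source reports. "The series", "measured", "known", "first", "only" and "open" are said of these compounds alone.

Compound 3 `Cc1ccc(CC2CCN(c3nc(C(F)(F)F)ccc3CNC(=O)C(C)c3ccc(NS(C)(=O)=O)c(F)c3)CC2)cc1` gives 17 nM in a functional assay on CHO-K1 cells for antagonist activity at transient receptor potential cation channel subfamily V member 1 (Homo sapiens), read by FLIPR (a higher number here means a weaker inhibitor, a lower number a stronger inhibitor), the lowest of the two numbers at hand. Compound 2 `CC(C(=O)NCc1ccc(C(F)(F)F)nc1N(C)c1ccccc1)c1ccc(NS(C)(=O)=O)c(F)c1` gives 57.4 nM in this assay, a gap from compound 3 that lies beyond the usual scatter. Compound 1 `CC(C(=O)NCc1ccc(C(F)(F)F)nc1NCc1cccnc1)c1ccc(NS(C)(=O)=O)c(F)c1` is reported in this assay as "not active" (no number reported), with no number attached. Compound 4 `CC(C(=O)NCc1ccc(C(F)(F)F)nc1N1CCC(O)CC1)c1ccc(NS(C)(=O)=O)c(F)c1` has not yet been tested; it differs from compound 3 in one place: hydroxy in place of 4-methylbenzyl on a saturated ring carbon. Among the compounds with values here, no measured pair in this set isolates that change, so its effect is unknown. The step from compound 3 to compound 4 is expected to be an 8.8-fold higher number from compound 3 to compound 4 (0.95 log units; beyond the scatter), toward a higher number and beyond the scatter. Compound 4 is estimated to give about 150 nM, between 40 nM and 600 nM.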

Compound 4, half-maximal inhibitory concentration: "not active" (no number reported)
The entry for compound 4 holds no number; the estimate stays without a comparison.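

Within the data shown here, compound 4 carries no number, so no step from compound 3 to compound 4 can be read, and no evidence bears on this result. The compounds shown leave open how large a change in this assay hydroxy in place of 4-methylbenzyl brings.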